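Remote Group Swap with Little Effect on Acid Dissociation

The compounds below may be only part of what the source reports. "The series", "measured", "known", "first", "only" and "open" are said of these compounds alone.

Compound 1, `COc1ccc(F)cc1CNCCCNc1ccnc2cc(Cc3cc(C)cc(C)c3)ccc12`, gives 9.47 in a physicochemical assay for acid dissociation.
Compound 2, `COc1ccc(F)cc1CNCCCNc1ccnc2cc(C3CCCCC3)ccc12`, gives 9.47 in this assay.
Compound 3, `COc1ccc(F)cc1CNCCCNc1ccnc2cc(Oc3ccc(F)cc3)ccc12`, gives 9.28 in this assay.

Compound 3 sits at the lower edge of these three numbers, yet a number 0.19 log units lower from compound 1 to compound 3 (within the scatter) and a number 0.19 log units lower from compound 2 to compound 3 (within the scatter) both lie within the scatter, so the three compounds cannot be told apart in this assay. Compound 4, `COc1ccc(F)cc1CNCCCNc1ccnc2cc(-c3ccc(C(C)(C)C)cc3)ccc12`, carries 4-(tert-butyl)phenyl in place of 4-fluorophenoxy on an aromatic carbon. Every measured step changed the group at this same aromatic carbon: no change at the digits printed from compound 1 to compound 2 (within the scatter), a number 0.19 log units lower from compound 1 to compound 3 (within the scatter) and a number 0.19 log units lower from compound 2 to compound 3 (within the scatter). None moved the acid dissociation constant beyond the scatter, so the step from compound 3 to compound 4 is expected to be a number 0.12 log units higher from compound 3 to compound 4 (within the scatter), with no real shift. Compound 4 is therefore estimated at 9.4, in the range 9.1 to 9.7.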

Compound 4, acid dissociation constant: 9.47
Estimate against measurement, compound 4: 0.07 log units below, and the stated range covers the measured number.
By their numbers in this assay, from the lowest: compounds 3, 1, 2 and 4 (each within the scatter of the next).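

In this assay the 4-(tert-butyl)phenyl group, with only carbon among its 10 heavy atoms, gives no step beyond the scatter against any earlier group at this aromatic carbon (a number 0.19 log units higher from compound 3 to compound 4 (within the scatter); no change at the digits printed from compound 2 to compound 4 (within the scatter); no change at the digits printed from compound 1 to compound 4 (within the scatter)). Losing the oxygen and fluorine of 4-fluorophenoxy therefore does not separate compound 4 from compound 3 here. No supporting measurement accounts for this result.

All four groups at this carbon are uncharged, so an amine or a carboxylic acid there remains an open case. The compounds shown also leave open any change to the propyl chain or the methoxy group.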